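The source may report more compounds than this note shows. Statements on the series, on what has been measured and on what is new or still open speak of the compounds shown alone.

Four compounds share one core, differing at the carbonyl substituent and on the aryl ring. Compound 1 `C=CC1=C(C(=O)NCC(C)C)C(c2ccc(OC)cc2)OC1` carries an amide with an isopropyl group on the chain carbon bound to the nitrogen, and compound 2 `C=CC1=C(C(=O)NCc2ccccc2)C(c2ccc(OC)cc2)OC1` carries a phenyl group at that carbon. In a functional assay on HeLa cells (Homo sapiens) for cytotoxicity, read by MTT assay, with a stated time of 24 h (a higher number here means a weaker inhibitor, a lower number a stronger inhibitor), compound 1 gives only a limit, > 100000 nM. In this assay compound 2 likewise gives only a limit, > 100000 nM. The step that the two limits leave unreadable from compound 1 to compound 2 therefore cannot be read, since both values sit at the limit of > 100000 nM in this assay, at which 2 of the 3 values shown sit. Among the compounds with values here, compound 3 `C=CC1=C(C(=O)O)C(c2ccc(OC)c(OC)c2)OC1` bears a carboxylic acid in place of the amide and two methoxy groups on the aryl ring; in this assay compound 3 gives 18000 nM, the only number among the three values.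

Compound 4 `C=CC1=C(C(=O)O)C(c2ccc(OC)cc2)OC1` differs from compound 3 by hydrogen in place of methoxy on an aromatic carbon. Within the data shown here, no measured step concerns a methoxy group on the aryl ring, and the one measured step, which concerns the amide substituent, is unreadable, so no measured step bears on this change. The estimated step is therefore a 1.4-fold higher number from compound 3 to compound 4 (0.14 log units; within the scatter), within the usual scatter, with no direction claimed. In this assay compound 4 is estimated at 25000 nM, expected to lie between 8000 nM and 100000 nM.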

Compound 4, half-maximal inhibitory concentration: 44300 nM
For compound 4 the middle estimate is 1.8-fold (0.25 log units) below the measured one, and the stated range covers the measured number.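

In this assay, the aromatic ring now has a readable step: hydrogen in place of methoxy, at the carbon ortho to a methoxy group, gives a 2.5-fold higher number from compound 3 to compound 4 (0.39 log units; beyond the scatter), a modest change beyond the scatter that shows this position is not indifferent to the group it carries. The carbonyl carbon also gains its first readings, since hydroxy in place of benzylamino gives an at least 2.2-fold lower number from compound 2 to compound 4 (0.35 log units; beyond the scatter), and hydroxy in place of isobutylamino gives an at least 2.2-fold lower number from compound 1 to compound 4 (0.35 log units; beyond the scatter), so the two amides, unreadable against each other, can now each be set against the carboxylic acid of compound 4. Both of these steps are bounds and not sizes, and the real gaps could be wider: the limit of > 100000 nM in this assay, at which 2 of the 4 values shown sit.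

The compounds shown leave open whether a methyl ester or an unsubstituted amide at the carbonyl carbon would give a number rather than a limit. They also leave open whether a hydroxy group or a fluorine in place of that methoxy group would move the value in this assay, and whether the methoxy step holds when the carbonyl carbon carries an amide.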